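Adding an Amino Group Lowers Growth Inhibition

This account rests on a few compounds, and the source may have more. Where it says the series, first, only, none or still open, it means among the compounds named here.

The compounds here share a two-ring core carrying a chloro group, joined through a short linker to a benzene ring that bears a chloromethyl group. Compound 1 `ClCc1ccc(Cn2cnc3c(Cl)ncnc32)cc1` was tested in a functional assay on RPMI-8226 cells (Homo sapiens) for cytotoxicity, read by sulforhodamine B assay, with a stated time of 48 h (a higher number here means a weaker inhibitor of growth, a lower number a stronger inhibitor of growth), where compound 1 gives 9340 nM. Compound 2 `Nc1nc(Cl)c2ncn(Cc3ccc(CCl)cc3)c2n1` differs from compound 1 in one place: amino in place of hydrogen on an aromatic carbon. In this assay compound 2 reaches only the limit of the measurement, > 100000 nM, and no number is known. The step is therefore an at least 10-fold higher number from compound 1 to compound 2 (1.02 log units; beyond the scatter), with the caveat that the limit of > 100000 nM in this assay, at which 1 of the 3 values shown sits, sets the ceiling for how large the step can be read.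

Compound 3 `ClCc1ccccc1Cn1cnc2c(Cl)ncnc21` has the same atoms as compound 1, joined differently; the difference between the two cores is not broken down here. In this assay, within the data shown here, compound 3 gives 40700 nM, the highest of the two numbers known, a step beyond the scatter from compound 1.

Compound 4 `Nc1nc(Cl)c2ncn(Cc3ccccc3CCl)c2n1` stands to compound 3 as compound 2 stands to compound 1: amino in place of hydrogen on an aromatic carbon. The change is the same, at the same place. Compound 4 is expected to show a step of a 6.1-fold higher number from compound 3 to compound 4 (0.79 log units; beyond the scatter), an expectation resting on the measured step of an at least 10-fold higher number from compound 1 to compound 2 (1.02 log units; beyond the scatter). Compound 4 is therefore estimated at 250000 nM, with a range of 100000 nM to 800000 nM, most likely reported only as a limit.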

Compound 4, concentration for total growth inhibition: > 100000 nM
Compound 4: only a limit was reported (the forecaster's own chance of this, stated with the estimate: 80%); the middle value is on the limit's open side.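

In this assay, amino in place of hydrogen on an aromatic carbon again gives a higher number, and so weaker growth inhibition, on the second core: the step is an at least 2.4-fold higher number from compound 3 to compound 4 (0.39 log units; beyond the scatter). So, in the two pairs shown, the direction of the change carries from one core to the other, and the two cases compare as follows: the same change on two cores in this assay, an at least 10-fold higher number (1.02 log units; beyond the scatter) from compound 1 to compound 2 and an at least 2.4-fold higher number (0.39 log units; beyond the scatter) from compound 3 to compound 4; the limit leaves it open whether they differ. This does not show that the size of the step carries over, or that one core responds more strongly than the other, because neither amino compound has an exact value: the limit of > 100000 nM in this assay, at which 2 of the 4 values shown sit.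

The compounds shown leave open how far growth inhibition falls on each core, and whether the same direction would hold on a core with the chloromethyl group replaced by a bromomethyl or a hydroxymethyl group. They also leave open whether a different group on that same aromatic carbon, such as a methyl group, a methoxy group or a dimethylamino group, would raise the number as the amino group does or leave it within the usual scatter.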